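Swapping an Aryl Amide for a Benzyl Amide

The source may report more compounds than this note shows. Statements on the series, on what has been measured and on what is new or still open speak of the compounds shown alone.

In a functional assay on the whole organism (strain C57BL/6) for inhibition, with Mus musculus as the target, read by paw edema, with stated times of 1 h and 4 h, at a dose of 100 mg/kg by the oral route (on this read-out higher numbers stand for more inhibition at the one dose given (going by the name of the read-out) and lower numbers for less inhibition), compound 1 `CC(=O)Nc1ccc(Cc2noc(CCC(=O)O)n2)cc1` gives 75.3%. Compound 2 `CC(=O)Nc1ccc(Cc2noc(CCC(=O)Nc3ccc(F)cc3)n2)cc1` gives 64.4%, the lowest of the three numbers at hand, and compound 3 `C#Cc1cccc(NC(=O)CCc2nc(Cc3ccc(NC(C)=O)cc3)no2)c1` gives 84.9%. Compound 4 `CC(=O)Nc1ccc(Cc2noc(CCC(=O)NCc3ccccc3)n2)cc1` has not yet been measured; it differs from compound 2 by benzyl in place of 4-fluorophenyl on an amide-type nitrogen. Two of the measured steps touch the same part of the molecule. The step of a number 10.9 percentage points lower from compound 1 to compound 2 (beyond the scatter) shows that putting (4-fluorophenyl)amino in place of hydroxy on the carbonyl carbon lowered the read-out, while a number 20.5 percentage points higher from compound 2 to compound 3 (beyond the scatter) shows that exchanging one aromatic group for another on the amide nitrogen raised it beyond the scatter. For the measured compounds named here, no measured compound carries a benzyl group, so the direction for compound 4 is uncertain, though the two steps suggest that compound 2 sits low and that a change on its amide nitrogen is more likely to move the number up than down. For compound 4 the expected step is a number 7.6 percentage points higher from compound 2 to compound 4 (within the scatter). Compound 4 is therefore estimated at 72%, within a range from 55% to 88%.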

Compound 4, a percentage reported as inhibition, in the whole organism at one dose (the size of the read-out at that dose, not a potency): 76.7%
Beside the measured number, compound 4's estimate is 4.7 percentage points below it, within the range that was stated.
By their numbers in this assay, from the lowest: compound 2; then compounds 1, 4 and 3 (each within the scatter of the next).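

Benzyl in place of 4-fluorophenyl on the amide-type nitrogen gives a number 12.3 percentage points higher from compound 2 to compound 4 (beyond the scatter) in this assay, even though both groups count the same heavy atoms and one aromatic ring of carbon. So this position can respond to a swap that leaves those counts unchanged. The benzylamino amide also stays level with the other two compounds, with a number 8.2 percentage points lower from compound 3 to compound 4 (within the scatter) on the aryl side and a number 1.4 percentage points higher from compound 1 to compound 4 (within the scatter) against the free acid, which shows that an amide at this carbonyl need not fall short of the acid; of the amides shown, only compound 2 does.

A plain phenyl or a longer chain such as 2-phenylethyl on this nitrogen would help show whether the loss of fluorine or the added carbon link matters here. No measurement offered here accounts for the shift seen with this swap.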